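The source may report more compounds than this note shows. Statements on the series, on what has been measured and on what is new or still open speak of the compounds shown alone.

Measured so far in a functional assay on HT-29 cells (Homo sapiens) for inhibition, read by MTT assay, with a stated time of 48 h; a higher number here means a weaker inhibitor, a lower number a stronger inhibitor:

Compound 1 `COc1ccc(-n2c(SCC(=O)c3ccc(OC)c(O)c3)nnc2-c2cc(OC)c(OC)c(OC)c2)cc1` — compound 1 gives > 60000 nM, which is a limit of the assay and not a number.
Compound 2 `COc1ccc(-n2c(SCC(=O)c3ccc4ccccc4c3)nnc2-c2cc(OC)c(OC)c(OC)c2)cc1` — compound 2 gives 53400 nM.
Compound 3 `COc1ccc(C(=O)CSc2nnc(-c3cc(OC)c(OC)c(OC)c3)n2-c2ccc(N(C)C)cc2)cc1O` — compound 3 gives > 60000 nM, again a limit of the assay.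

The one readable step among these is the change (naphthalen-2-yl in place of 3-hydroxy-4-methoxyphenyl on a carbonyl carbon), which gave an at least 1.1-fold lower number from compound 1 to compound 2 (0.05 log units; that floor lies within the scatter). The cores of compound 1 and compound 3 differ by dimethylamino in place of methoxy on an aromatic carbon; that step is a step that the two limits leave unreadable from compound 1 to compound 3, since both ends are limits. Overall the series sits at the edge of what this assay can resolve: the limit of > 60000 nM in this assay, at which 2 of the 3 values shown sit.

Compound 4 `COc1cc(-c2nnc(SCC(=O)c3ccc4ccccc4c3)n2-c2ccc(N(C)C)cc2)cc(OC)c1OC` is not yet measured. It carries the change naphthalen-2-yl in place of 3-hydroxy-4-methoxyphenyl on a carbonyl carbon on the core of compound 3. The place is the same word for word as for the change from compound 1 to compound 2, so this is the same change, made a second time, and the series shows it twice in all.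

Compound 4 is expected to give a step of an at least 1.0-fold lower number from compound 3 to compound 4 (0.03 log units; that floor lies within the scatter), and that rests on the earlier step of an at least 1.1-fold lower number from compound 1 to compound 2 (0.05 log units; that floor lies within the scatter), whose floor lies within the scatter. Compound 4 is thus expected to land near 55000 nM, with a range from 30000 nM to 100000 nM, and a fair chance that this assay returns only a limit for compound 4 rather than a number.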

Compound 4, half-maximal inhibitory concentration: > 60000 nM
Compound 4: only a limit was reported; the forecaster's own chance of this, stated with the estimate: 50%; middle value at least 1.0-fold (0.03 log units) away from the limit.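

In this assay compound 4 gives > 60000 nM, which is a limit of the assay and not a number. The second making of the change, naphthalen-2-yl in place of 3-hydroxy-4-methoxyphenyl on a carbonyl carbon, cannot be read on the core of compound 3 because both ends of that step are limits, so the series shows neither that the change carries from one core to the other nor that it fails to carry: the limit of > 60000 nM in this assay, at which 3 of the 4 values shown sit. Within the data shown here, the one new step that can be read is dimethylamino in place of methoxy on an aromatic carbon, with an at least 1.1-fold higher number from compound 2 to compound 4 (0.05 log units; that floor lies within the scatter), which gives a floor and no measured size, and so shows no separation between the two compounds.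

The compounds shown leave open whether the naphthalen-2-yl change would behave alike on two cores if both ends of each step gave numbers in this assay, since only one end of one step here carries a number. They also leave open whether a carboxylic acid or an amine on the aromatic ring at the carbonyl, or a longer chain in place of the saturated chain carbon, would give values clear of this limit, where steps could be sized.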